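This account rests on a few compounds, and the source may have more. Where it says the series, first, only, none or still open, it means among the compounds named here.

Measured in an ADME assay on L132 cells (Homo sapiens) for cytotoxicity, read by MTT assay, with a stated time of 72 h; a lower number here means a stronger inhibitor, a higher number a weaker inhibitor:
compound 1 `COc1ccc(C2=C(c3cc(OC)c(OC)c(OC)c3)C(=O)C(O[SiH2]C(C)(C)C)C2)cc1`: 9 ug/mL
compound 2 `COc1ccc(C2=C(c3cc(OC)c(OC)c(OC)c3)C(=O)C(O[SiH2]C(C)(C)C)C2)cc1OC(C)C`: 7 ug/mL

Compound 2, at 7 ug/mL, stands level with compound 1, at 9 ug/mL. The two values lie within the scatter of each other.

Next is compound 3 `COc1cc(C2=C(c3ccc(SC)cc3)CC(O[SiH2]C(C)(C)C)C2=O)cc(OC)c1OC`, with the change 4-(methylsulfanyl)phenyl in place of 3-isopropoxy-4-methoxyphenyl on a double-bonded ring carbon.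

Going by the values given here, only one measured step bears on this: a 1.3-fold lower number from compound 1 to compound 2 (0.11 log units; within the scatter). It adds isopropoxy to the aromatic ring that is now replaced, and it stays within the scatter. Among the compounds with values here, no measured compound carries 4-(methylsulfanyl)phenyl, so the evidence is thin. No step beyond the scatter is expected in this assay, in either direction, but the range is kept wide.

The estimated step is a 1.1-fold higher number from compound 2 to compound 3 (0.06 log units; within the scatter).

For compound 3 the estimate is 8 ug/mL, with an expected range of 3.5 ug/mL to 18 ug/mL.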

Compound 3, half-maximal inhibitory concentration: < 1 ug/mL
Compound 3 ended at the assay's limit; the forecaster's own chance of this, stated with the estimate: 5%; middle value at least 8.0-fold (0.90 log units) from the limit.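

Going by these compounds alone, the change to 4-(methylsulfanyl)phenyl on the double-bonded ring carbon gives an at least 7.0-fold lower number from compound 2 to compound 3 (0.84 log units; beyond the scatter) in this assay and is the first change to move the number beyond the scatter, which the isopropoxy step did not do. Methylsulfanyl in place of methoxy on the aromatic carbon gives an at least 9.0-fold lower number from compound 1 to compound 3 (0.95 log units; beyond the scatter) on its own, so this step does not rest on the removal of isopropoxy. Compound 3 stands at < 1 ug/mL, a limit of the assay and not a number: the limit of < 1 ug/mL in this assay, at which 1 of the 3 values shown sits.

As far as these compounds go, how far compound 3 lies past that limit remains open, and the full size of both steps with it. Also open, from the compounds shown here alone, is whether an ethylsulfanyl group, a longer chain on the sulfur, or an amine at the same ring position would keep this step.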